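The compounds below may be only part of what the source reports. "The series", "measured", "known", "first", "only" and "open" are said of these compounds alone.

In an assay on HEK293 cells for inhibition of Steryl-sulfatase (Homo sapiens), tested at 0.1 uM (on this read-out higher numbers stand for a stronger effect at the one concentration tested and lower numbers for a weaker effect), compound 2 `CCN(Cc1cccnc1)c1cccc(C(=O)N2CCc3ccc(OS(N)(=O)=O)cc3C2)c1` gives 14.3%. Compound 1 `CCN(Cc1cccc(Br)c1)c1cccc(C(=O)N2CCc3ccc(OS(N)(=O)=O)cc3C2)c1` gives 20.9% in this assay, and these two numbers lie within the usual scatter of each other, so compound 2 stands level with compound 1. Compound 3 `NS(=O)(=O)Oc1ccc2c(c1)CN(C(=O)c1cccc(N3CCc4ccccc4C3)c1)CC2` differs from compound 2 in one place: 1,2,3,4-tetrahydroisoquinolin-2-yl in place of ethyl((pyridin-3-yl)methyl)amino on an aromatic carbon. Going by the values given here, the only measured step, a number 6.6 percentage points lower from compound 1 to compound 2 (within the scatter), swapped the pendant ring on the same side of the core and stayed within the scatter, which is a weak guide for a change that removes that arm altogether. Compound 3 is therefore expected to show a number 0.7 percentage points higher from compound 2 to compound 3 (within the scatter), that is, no step beyond the scatter, with an estimated value of 15% and a range from 3% to 30%.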

Compound 3, a percentage reported as inhibition, at one concentration (the size of the read-out at that concentration, not a potency): 24.1%
Estimate against measurement, compound 3: 9.1 percentage points below, within the range that was stated.
By their numbers in this assay, from the lowest: compounds 2, 1 and 3 (each within the scatter of the next).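

In (this assay), placing 1,2,3,4-tetrahydroisoquinolin-2-yl on this aromatic carbon in place of ethyl((pyridin-3-yl)methyl)amino gives (a number 9.8 percentage points higher from compound 2 to compound 3 (within the scatter)), and in place of (3-bromobenzyl)(ethyl)amino gives (a number 3.2 percentage points higher from compound 1 to compound 3 (within the scatter)). So this position tolerates a fused ring system as well as an open substituted amine, with no change that can be read beyond the scatter. No evidence here explains this result. From the compounds shown here alone, it remains open whether a smaller group on this carbon, such as morpholine or a plain dimethylamino, would shift the read-out beyond the scatter. Going by these compounds, a carboxylic acid there is equally open.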